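Removing a dichlorobenzyl group from a bis-allyl biphenyl

The source may hold more compounds than are shown below. What is called first, only, known or untested is meant among the compounds shown, and "the series" means these compounds.

Measured compounds:
- compound 1, `C=CCc1ccc(O)c(-c2ccc(OCc3c(Cl)cccc3Cl)c(CC=C)c2)c1`, gives 16600 nM in a functional assay on I10 cells (Mus musculus) for inhibition, read by MTT assay, with a stated time of 72 h; on this read-out lower numbers stand for stronger inhibition and higher numbers for weaker inhibition
- compound 2, `C=CCc1ccc(OCc2ccc(Cl)cc2Cl)c(-c2ccc(OCc3ccc(Cl)cc3Cl)c(CC=C)c2)c1`, gives > 50000 nM in this assay; this is a limit of the assay, not a number
- compound 3, `C=CCc1ccc(OCc2c(Cl)cccc2Cl)c(-c2ccc(OCc3c(Cl)cccc3Cl)c(CC=C)c2)c1`, gives > 50000 nM in this assay; this too is a limit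

Compound 2 therefore stands at the weak end of what has been seen: its value is only a limit, and it shares that limit with compound 3 (the limit of > 50000 nM in this assay, at which 2 of the 3 values shown sit). Compound 1, which carries a free hydroxy group on one ring, is the only one of the three with a measured number.

The unmeasured compound 4, `C=CCc1ccc(O)c(-c2ccc(OCc3ccc(Cl)cc3Cl)c(CC=C)c2)c1`, differs from compound 2 in one place (hydrogen in place of 2,4-dichlorobenzyl on an oxygen on an aromatic ring). For the measured compounds named here, one measured step bears on this: going from compound 1 to compound 3, a 2,6-dichlorobenzyl replaced a hydrogen on the same kind of oxygen, and the number rose an at least 3.0-fold higher number from compound 1 to compound 3 (0.47 log units; beyond the scatter). The change from compound 2 to compound 4 runs the other way, so the number is expected to fall, by roughly the mirror of that step, giving an expected step of an at least 2.9-fold lower number from compound 2 to compound 4 (0.46 log units; beyond the scatter). Compound 4 is thus estimated at 17000 nM, in the range 5000 nM to 50000 nM.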

Compound 4, half-maximal inhibitory concentration: 10400 nM
Compound 4: middle estimate off by 1.6-fold (0.21 log units), on the high side; low and high end bracket the measured number.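

For the compounds shown here, replacing 2,4-dichlorobenzyl with hydrogen on this oxygen gives an at least 4.8-fold lower number from compound 2 to compound 4 (0.68 log units; beyond the scatter) in this assay, so the link between losing the benzyl group and stronger inhibition, so far seen only with the 2,6-dichlorobenzyl pair, now holds for a second chlorine pattern. The full size of this step cannot be given because compound 2 gives only a limit, not a number: the limit of > 50000 nM in this assay, at which 2 of the 4 values shown sit. Compound 4 also allows a comparison of the two chlorine patterns on the remaining benzyl group, and a 1.6-fold lower number from compound 1 to compound 4 (0.20 log units; within the scatter) shows that the pattern makes no difference that can be told from the scatter.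

The compounds shown do not separate any contribution of the free hydroxy group itself from the simple absence of a dichlorobenzyl group, a question that a methoxy group or an unsubstituted benzyl group on this oxygen would address. They also leave open what an amine in place of the hydroxy group would do, and what would happen if the second dichlorobenzyl group were also replaced with hydrogen.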